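The compounds below may be only part of what the source reports. "The series", "measured", "known", "first", "only" and "open" are said of these compounds alone.

Measured compounds:
Compound 1, `CN(C)CCn1cnnc1-c1cc(Oc2ccc(NC(=O)Nc3cccc(C(F)(F)F)c3)cc2F)ccn1`, gives 2150 nM.
Compound 2, `CN(C)CCn1cnnc1-c1cc(Oc2ccc(NC(=O)Nc3ccc(F)c(Cl)c3)cc2F)ccn1`, gives 1580 nM.
Compound 3, `CN(C)CCn1cnnc1-c1cc(Oc2ccc(NC(=O)Nc3ccc(Cl)cc3Cl)cc2F)ccn1`, gives 4350 nM.

All three were tested in a functional assay on NCI-H460 cells (Homo sapiens) for antiproliferative activity, read by MTT assay, with a stated time of 72 h; a lower number here means a stronger inhibitor, a higher number a weaker inhibitor. Compound 1 stands second highest of the three numbers. Its nearest neighbour is compound 2, reached by a 1.4-fold lower number from compound 1 to compound 2 (0.13 log units; within the scatter); its furthest is compound 3, reached by a 2.0-fold higher number from compound 1 to compound 3 (0.31 log units; beyond the scatter). Between those two, a 2.8-fold higher number from compound 2 to compound 3 (0.44 log units; beyond the scatter). Every one of these steps swaps the aryl group on the amide-type nitrogen; the amine on the chain at the other end of the shared core is the same in all three.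

Compound 4, `CCN(CC)CCn1cnnc1-c1cc(Oc2ccc(NC(=O)Nc3cccc(C(F)(F)F)c3)cc2F)ccn1`, keeps the aryl group of compound 1 and changes only that amine: diethylamino in place of dimethylamino on a saturated chain carbon, two bonds along the chain from an aromatic nitrogen. For the measured compounds named here, no measured step touches this part of the molecule, so nothing among the measured compounds shows how this assay answers to a change there. With no guide in either direction, the expectation is a step no larger than the usual scatter, and compound 4 is estimated at 2100 nM, with a range of 1000 nM to 4500 nM. This estimate means an expected 1.0-fold lower number from compound 1 to compound 4 (0.01 log units; within the scatter).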

Compound 4, half-maximal inhibitory concentration: 9870 nM
Compound 4: middle estimate off by 4.7-fold (0.67 log units), on the low side; measured number above the stated range.
By their numbers in this assay, from the lowest: compounds 2 and 1 (each within the scatter of the next); then compound 3; then compound 4.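

In this assay, the amine at the end of the chain turns out not to be a silent spot: diethylamino in place of dimethylamino, a change from 3 heavy atoms to 5 with the rest of the molecule untouched, gives a 4.6-fold higher number from compound 1 to compound 4 (0.66 log units; beyond the scatter) and so a clearly weaker inhibitor. This single change on the chain moves the number further than the largest step seen among the aryl groups on the amide-type nitrogen (a 2.8-fold higher number from compound 2 to compound 3 (0.44 log units; beyond the scatter)), so this end of the molecule deserves at least as much attention as the aryl end. Nothing measured on these two amines is available to account for the drop, so its reason stays unknown.

The compounds shown leave open whether the trend continues in either direction along the amine, for instance with a smaller methylamino group, a ring amine such as pyrrolidine or morpholine, or a longer chain between the amine and the shared core. They also leave open whether diethylamino costs as much when paired with the 3-chloro-4-fluorophenyl or 2,4-dichlorophenyl group as it does with 3-(trifluoromethyl)phenyl.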